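A few compounds are considered here, and "the series" means these few. Any claim that something is new, unique, unknown or untested is made for them only; others in the source may bear on it.

Compound 1 `O=C(OC1(C(=O)Nc2ccc([N+](=O)[O-])cc2)CCCCC1)c1ccc([N+](=O)[O-])cc1` gives the lowest number of the two measured compounds in a functional assay on HepG2 cells (Homo sapiens) for inhibition, read by MTT assay, with a stated time of 72 h (a higher number here means a weaker inhibitor, a lower number a stronger inhibitor), at 14.1 nM. Among the compounds with values here, the only other measured compound, compound 2 `CCOC(=O)c1ccccc1C(=O)OC1(C(=O)Nc2ccc([N+](=O)[O-])cc2)CCCCC1`, gives 517 nM in this assay, a gap that lies well beyond the scatter, and no single-point step connects the two. Compound 3 `O=C(OC1(C(=O)Nc2ccc([N+](=O)[O-])cc2)CCCCC1)C(O)c1ccccc1` is not yet measured; it differs from compound 1 in one place: hydroxy(phenyl)methyl in place of 4-nitrophenyl on a carbonyl carbon. No measured pair isolates this change, so the expectation can rest only on the two numbers shown: compound 1 carries the 4-nitrophenyl and holds the low value, while compound 2, with a different ester, sits far higher at 517 nM. The change is therefore expected to raise the number in this assay by a step beyond the scatter, a 21-fold higher number from compound 1 to compound 3 (1.33 log units; beyond the scatter), though its size is uncertain. Compound 3 is estimated at 300 nM in this assay, within a range from 50 nM to 2000 nM.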

Compound 3, half-maximal inhibitory concentration: 7.7 nM
Compound 3: the middle estimate sits 39-fold (1.59 log units) above what was measured; measured number below the stated range.
By their numbers in this assay, from the lowest: compounds 3 and 1 (each within the scatter of the next); then compound 2.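

Exchanging 4-nitrophenyl for hydroxy(phenyl)methyl on a carbonyl carbon gives a 1.8-fold lower number from compound 1 to compound 3 (0.26 log units; within the scatter) in this assay. At this position, then, a low number in this assay does not depend on the 4-nitrophenyl group: compound 3 has no nitro group, and it carries a hydroxy group on the carbon that joins its phenyl ring to the carbonyl. Nothing at hand accounts for why these two different groups read alike in this assay.

The compounds shown leave open what the hydroxy group itself contributes, which a benzyl group or a methoxy(phenyl)methyl group at this place would help to settle. They also leave open whether an amine or a carboxylic acid in place of that hydroxy group would keep the number this low.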